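A few compounds are considered here, and "the series" means these few. Any claim that something is new, unique, unknown or untested is made for them only; others in the source may bear on it.

Compounds measured so far:

Compound 1 `CCCCCNc1cccc2c(S(=O)(=O)Nc3onc(C)c3C)cccc12` — 80 nM in an assay on VSM-A10 cells for antagonist activity at Endothelin-1 receptor (Rattus norvegicus); a lower number here means a stronger inhibitor, a higher number a weaker inhibitor
Compound 2 `Cc1onc(NS(=O)(=O)c2cccc3c(N(C)C)cccc23)c1C` — 60 nM
Compound 3 `Cc1noc(NS(=O)(=O)c2cccc3c(N(C)C)cccc23)c1Cc1ccccc1` — 50000 nM

Compound 1 stands second highest of the three values. Its nearest neighbour is compound 2, whose value lies within the scatter of compound 1, so no order between the two can be read. Compound 3 stands far higher than compound 1, beyond the scatter; compound 3 differs from compound 1 in more than one place, so its two values show only that the gap is large, not what drives it.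

The step from compound 1 leads to compound 4 `Cc1noc(NS(=O)(=O)c2cccc3ccccc23)c1C`, not yet measured. The change is hydrogen in place of pentylamino on an aromatic carbon. Within the data shown here, no measured pair shows this change on its own, so the size of the step can only be expected. Both compound 1 and compound 2 carry a substituent at that aromatic carbon and both sit in the same region of values; compound 4 carries none. A loss of potency beyond the scatter is therefore expected, though its extent is uncertain. Compound 4 is estimated at 600 nM, between 120 nM and 3000 nM, the expected step being a 7.5-fold higher number from compound 1 to compound 4 (0.88 log units; beyond the scatter).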

Compound 4, half-maximal inhibitory concentration: 20000 nM
For compound 4 the middle estimate is 33-fold (1.52 log units) below the measured one, and the stated range ends below it.
By their numbers in this assay, from the lowest: compounds 2 and 1 (each within the scatter of the next); then compound 4; then compound 3.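

In this assay, hydrogen in place of pentylamino on the aromatic carbon gives a 250-fold higher number from compound 1 to compound 4 (2.40 log units; beyond the scatter). Among these compounds, this is the first step in the set that isolates a single change, and it shows that a substituent at this carbon matters greatly: the large step comes from this one change alone, with the rest of the molecule held constant. No measured evidence here explains the size of this step.

As far as these compounds go, it remains open whether the nitrogen or the pentyl chain accounts for the step, since a primary amine, a methoxy group or a plain butyl chain at this carbon would help to separate the two. Compound 2 carries dimethylamino there but differs from compound 1 in more than one place, so it cannot settle how much the chain length matters.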